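A Urea in Place of the Piperazinone on the Aminomethyl Arm

This account rests on a few compounds, and the source may have more. Where it says the series, first, only, none or still open, it means among the compounds named here.

Of the compounds shown here, three that share one core have been measured in an assay on isolated protein for displacement of a labelled ligand from 5-hydroxytryptamine receptor 6 (Homo sapiens); on this read-out higher numbers stand for weaker inhibition and lower numbers for stronger inhibition. Compound 1 `COc1cccc(S(=O)(=O)c2ccc3c(c2)CCC[C@H]3CN)c1` gives 0.398 nM. Compound 2 `NC[C@@H]1CCCc2cc(S(=O)(=O)c3cn[nH]c3)ccc21` gives 2 nM. Compound 3 `O=C1CN(C[C@@H]2CCCc3cc(S(=O)(=O)c4cccc(F)c4)ccc32)CCN1` gives 6.31 nM, the highest of the three numbers; compound 2 is its nearest neighbour, already beyond the usual scatter, and compound 1 lies furthest from it, also beyond the scatter.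

Compound 4 `CN(C)C(=O)NC[C@@H]1CCCc2cc(S(=O)(=O)c3cccc(F)c3)ccc21` differs from compound 3 in one place: (dimethylcarbamoyl)amino in place of 3-oxopiperazin-1-yl on a saturated chain carbon bound to a saturated ring carbon. For the measured compounds named here, no measured pair shows this change, so its effect is uncertain. The expected step is a 4.8-fold higher number from compound 3 to compound 4 (0.68 log units; beyond the scatter), a move towards weaker inhibition. Compound 4 is estimated at 30 nM, with a range from 5 nM to 200 nM.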

Compound 4, inhibition constant: 2.51 nM
Compound 4: the middle estimate sits 12-fold (1.08 log units) above what was measured; the whole stated range lies above it.
By their numbers in this assay, from the lowest: compound 1; then compounds 2 and 4 (each within the scatter of the next); then compound 3.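

For the compounds shown here, the first step at this position, a 2.5-fold lower number from compound 3 to compound 4 (0.40 log units; beyond the scatter), shows that in this assay the ring of 3-oxopiperazin-1-yl is not required here: the ring-free (dimethylcarbamoyl)amino group takes its place with a modest gain in inhibition. Going by these compounds alone, the change therefore moves the number in the stronger direction, though only this one pair supports that reading. Nothing shown accounts for the step.

As far as these compounds go, it remains open how an acetamide or a urea with longer chains on its nitrogen would read on the same core. From the compounds shown here alone, whether the step would hold with the methoxy-bearing sulfonyl group of compound 1 also remains open.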